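Swapping Bromo for Methoxycarbonyl on a Shared Core

This account rests on a few compounds, and the source may have more. Where it says the series, first, only, none or still open, it means among the compounds named here.

Compound 1, `O=C(O)Cn1c(SCc2ccc(Br)cc2)nc2ccccc21`: 220 nM
Compound 2, `O=C(O)Cn1c(SCc2ccccc2Br)nc2ccccc21`: 580 nM
Compound 3, `COC(=O)c1ccc(CSc2nc3ccccc3n2CC(=O)O)cc1`: 10600 nM

These three values come from an assay on HEK293 cells for displacement of a labelled ligand from prostaglandin D2 receptor 2 (Homo sapiens); on this read-out lower numbers stand for stronger inhibition and higher numbers for weaker inhibition. Compounds 1 and 2 share every atom and differ only in how they are joined: 2-bromophenyl in place of 4-bromophenyl on a saturated chain carbon bound to a sulfur. That rearrangement gives a 2.6-fold higher number from compound 1 to compound 2 (0.42 log units; beyond the scatter). A second change, from compound 1 to compound 3, is methoxycarbonyl in place of bromo on an aromatic carbon, and it costs much more, with a 48-fold higher number from compound 1 to compound 3 (1.68 log units; beyond the scatter).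

The unmeasured compound 4, `COC(=O)c1ccccc1CSc1nc2ccccc2n1CC(=O)O`, is made from compound 2 by the same kind of change: methoxycarbonyl in place of bromo on an aromatic carbon. The difference is the surroundings of the place: in compound 3 the new group sits para to a large group, in compound 4 it sits ortho to a large group. Among the compounds with values here, only one example of this swap has been measured, so the expectation rests on it alone. The step from compound 2 to compound 4 is expected to be a 34-fold higher number from compound 2 to compound 4 (1.54 log units; beyond the scatter), a large loss, because the same swap gave a 48-fold higher number from compound 1 to compound 3 (1.68 log units; beyond the scatter). Compound 4 is therefore estimated at 20000 nM, most likely between 5000 nM and 80000 nM.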

Compound 4, half-maximal inhibitory concentration: 520 nM
The estimate for compound 4 lay 38-fold (1.59 log units) above the measured number; the measured number lies below the stated range.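

In this assay, putting methoxycarbonyl in place of bromo on an aromatic carbon ortho to a large group gives no difference that can be told from the usual scatter of repeated measurements, with a 1.1-fold lower number from compound 2 to compound 4 (0.05 log units; within the scatter). The large loss seen on the core of compound 1 therefore does not carry over to the core of compound 2, so the same swap cannot be treated as having one fixed cost in this series: the same change on two cores in this assay, a 48-fold higher number (1.68 log units; beyond the scatter) from compound 1 to compound 3 and a 1.1-fold lower number (0.05 log units; within the scatter) from compound 2 to compound 4, 54-fold (1.73 log units) apart, beyond the scatter of two such steps. This shows that the outcome of the swap depends on where the bromo stood on the ring, but two pairs of compounds do not show why the two steps part, and they give no rule for any further core.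

The compounds shown leave open whether this place accepts only methoxycarbonyl or also other groups, such as a nitrile, an amide or an amine. They also leave open how the same swap would behave at the remaining places on that ring.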